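This account rests on a few compounds, and the source may have more. Where it says the series, first, only, none or still open, it means among the compounds named here.

Of the compounds shown here, two built on one shared core have been measured in an assay on CHO cells for displacement of a labelled ligand from adenosine receptor A1 (Homo sapiens), read by scintillation counting, with a stated time of 3 h; on this read-out lower numbers stand for stronger inhibition and higher numbers for weaker inhibition. Compound 1 `Cn1c(-c2ccc(F)cc2)nc2c(NC3CCCC3)ncnc21` gives 6.2 nM, and compound 2 `CCn1c(-c2ccccc2)nc2c(NC3CCCCC3)ncnc21` gives 10 nM; these two numbers lie within the usual scatter of each other, so neither can be called the stronger binder. Compound 3 `Cn1c(-c2cccc(Cl)c2)nc2c(NC3CCCC3)ncnc21` has not yet been measured. It differs from compound 1 in one place: 3-chlorophenyl in place of 4-fluorophenyl on an aromatic carbon. Among the measured compounds shown here, no measured pair shows the effect of such a swap, so the step is expected to be modest, a 1.6-fold higher number from compound 1 to compound 3 (0.21 log units; within the scatter), not clearly beyond the scatter. Compound 3 is accordingly estimated at 10 nM, with a likely range from 3 nM to 35 nM.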

Compound 3, inhibition constant: 6.5 nM
Compound 3: middle estimate off by 1.5-fold (0.19 log units), on the high side; measured number inside the range.
By their numbers in this assay, from the lowest: compounds 1, 3 and 2 (each within the scatter of the next).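

Among the compounds shown here, the step of a 1.0-fold higher number from compound 1 to compound 3 (0.02 log units; within the scatter) comes with 3-chlorophenyl in place of 4-fluorophenyl on this aromatic carbon, and it gives the first direct comparison at this position in this assay. Here, the two substituted phenyl groups cannot be told apart. Nothing available explains this result.
The two groups differ in both the halogen and its place on the phenyl ring, so the effect of each remains unseparated. Also open, on these data alone, is how this position responds to a phenyl ring carrying an amine or a carboxylic acid.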